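Aryl swap on the sulfonyl sulfur: compound 1 to compound 3

The compounds below may be only part of what the source reports. "The series", "measured", "known", "first", "only" and "open" are said of these compounds alone.

Compound 1 `Cc1ccc(S(=O)(=O)c2cnc3cc(Cl)ccc3c2N2CCC(C)CC2)cc1F` holds the higher of the two numbers recorded in an assay on isolated protein for displacement of a labelled ligand from metabotropic glutamate receptor 5 (Homo sapiens), with a stated time of 60 min, tested at 1 uM; a lower number here means less inhibition, a higher number more inhibition at the concentration tested (going by the name of the read-out): compound 1 gives 85%. Compound 2 `Cc1ccc2ncc(S(=O)(=O)c3cc(F)cc(F)c3)c(N3CCC(C)CC3)c2c1` is the nearest, and in this assay compound 2 gives 72%, a gap that lies beyond the usual scatter. For the measured compounds named here, compound 2 differs from compound 1 in more than one place, so no single step is drawn between them; the two values show only that compound 1 stands above compound 2.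

Compound 3 `CC1CCN(c2c(S(=O)(=O)c3ccc(F)cc3)cnc3cc(Cl)ccc23)CC1` has not yet been measured. Its change from compound 1 is 4-fluorophenyl in place of 3-fluoro-4-methylphenyl on a sulfonyl sulfur. Going by the values given here, no step between measured compounds covers this change, so the direction rests on expectation alone. A small fall in this assay, possibly within the scatter, is estimated as a number 7 percentage points lower from compound 1 to compound 3 (within the scatter). Compound 3 is therefore expected to give 78% in this assay, with a range from 60% to 92%.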

Compound 3, a percentage reported as inhibition, at one concentration (the size of the read-out at that concentration, not a potency): 91%
Compound 3: middle estimate off by 13 percentage points, on the low side; low and high end bracket the measured number.
By their numbers in this assay, from the lowest: compound 2; then compounds 1 and 3 (each within the scatter of the next).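

In this assay, for the compounds shown here, 4-fluorophenyl in place of 3-fluoro-4-methylphenyl on a sulfonyl sulfur gives a number 6 percentage points higher from compound 1 to compound 3 (within the scatter), the first single-place step. The aryl group at this position can therefore lose one heavy atom, going from 8 to 7, with no shift beyond the scatter, and compound 1 and compound 3 cannot be ordered on this read-out. Nothing available bears on why the number holds across this swap.

Still open is how far this position stretches: the compounds shown carry only fluorinated phenyl groups on the sulfonyl sulfur, so an aryl group bearing a carboxylic acid or an amine, or a saturated ring such as cyclohexyl, remains untested in these notes. A read-out at one concentration also leaves the potency of compound 1 and compound 3 undefined.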